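Capping a Second Phenol: From Compound 1 to Compound 4

A few compounds are considered here, and "the series" means these few. Any claim that something is new, unique, unknown or untested is made for them only; others in the source may bear on it.

Compound 1 `COc1cc(/C=N/NC(=O)CCCc2nc3ccccc3c(=O)[nH]2)cc(O)c1O` gives 80000000 nM in a physicochemical assay, read by spectrophotometry, with a stated time of 15 min (a lower number here means a stronger inhibitor, a higher number a weaker inhibitor), the second highest of the three numbers measured here. Among the compounds with values here, compound 2 `O=C(CCCc1nc2ccccc2c(=O)[nH]1)N/N=C/c1cc(O)c(O)c(O)c1` gives 45000000 nM in this assay, and compound 3 `COc1cc(/C=N/NC(=O)CCc2nc3ccccc3c(=O)[nH]2)ccc1O` gives 290000000 nM; compound 3 also differs from compound 1 in its chain, so no single step separates them. Compound 4 `COc1cc(/C=N/NC(=O)CCCc2nc3ccccc3c(=O)[nH]2)cc(OC)c1O` differs from compound 1 by methyl in place of hydrogen on an oxygen on an aromatic ring, the same difference that, cut one bond further out, reads hydroxy to methoxy. Within the data shown here, the only comparable step, a 1.8-fold lower number from compound 1 to compound 2 (0.25 log units; within the scatter), runs the other way and stayed within the scatter, so adding a methyl is expected to shift the number little, if at all, perhaps slightly upward. The expected step is a 1.5-fold higher number from compound 1 to compound 4 (0.18 log units; within the scatter). Compound 4 is estimated at 120000000 nM, within a range from 50000000 nM to 300000000 nM.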

Compound 4, half-maximal inhibitory concentration: 225000000 nM
For compound 4 the middle estimate is 1.9-fold (0.27 log units) below the measured one, within the range that was stated.
By their numbers in this assay, from the lowest: compounds 2 and 1 (each within the scatter of the next); then compounds 4 and 3 (each within the scatter of the next).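

The step of a 2.8-fold higher number from compound 1 to compound 4 (0.45 log units; beyond the scatter) shows that capping this hydroxy as methoxy can move the number beyond the scatter, toward weaker inhibition. The earlier step of a 1.8-fold lower number from compound 1 to compound 2 (0.25 log units; within the scatter) involved the same kind of change, in the opposite direction, on a different oxygen, and stayed within the scatter. No measurement available here explains this shift. From the compounds shown here alone, whether an ethyl group on this oxygen would raise the number further remains open. So does the effect of an amine in place of this hydroxy.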